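The source may report more compounds than this note shows. Statements on the series, on what has been measured and on what is new or still open speak of the compounds shown alone.

Compound 2 `Cc1cc(C(=O)c2ccc(F)cc2)ccc1OCC(=O)Nc1nc(-c2ccccc2)cs1` gives 37400 nM in a functional assay on Ehrlich cells (Mus musculus) for cytotoxicity, read by MTT assay, with a stated time of 48 h (on this read-out lower numbers stand for stronger inhibition and higher numbers for weaker inhibition), at the high end of the three numbers to hand. Compound 1 `Cc1ccc(C(=O)c2ccc(OCC(=O)Nc3nc(-c4ccccc4)cs3)c(C)c2)cc1` gives 29900 nM; the step of a 1.3-fold higher number from compound 1 to compound 2 (0.10 log units; within the scatter) changed the ring that sits on the carbonyl and stayed within the scatter. Compound 3 `COc1ccc(-c2csc(NC(=O)COc3ccc(C(=O)c4ccc(F)cc4)cc3C)n2)cc1` gives 5400 nM; the step of a 6.9-fold lower number from compound 2 to compound 3 (0.84 log units; beyond the scatter) came from a methoxy on a different ring. Compound 4 `Cc1cc(C(=O)c2ccccc2F)ccc1OCC(=O)Nc1nc(-c2ccccc2)cs1` differs from compound 2 by 2-fluorophenyl in place of 4-fluorophenyl on a carbonyl carbon. Only the first measured step touched this ring, and no measured pair moves the fluorine within it, so the numbers to hand give no reason to expect a shift beyond the scatter. The expected step is a 1.1-fold lower number from compound 2 to compound 4 (0.03 log units; within the scatter). Compound 4 is estimated at 35000 nM, with a range from 14000 nM to 90000 nM.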

Compound 4, half-maximal inhibitory concentration: 16700 nM
Estimate against measurement, compound 4: 2.1-fold (0.32 log units) above; measured number inside the range.
By their numbers in this assay, from the lowest: compound 3; then compounds 4, 1 and 2 (each within the scatter of the next, the first and the last beyond it).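

In this assay, 2-fluorophenyl in place of 4-fluorophenyl on the carbonyl carbon gives a 2.2-fold lower number from compound 2 to compound 4 (0.35 log units; beyond the scatter) and shows that this ring responds, modestly, to where its fluorine stands, which the earlier methyl-to-fluoro step did not reveal. Against 4-methylphenyl, 2-fluorophenyl gives a 1.8-fold lower number from compound 1 to compound 4 (0.25 log units; within the scatter) and so does not separate the two compounds. No available evidence bears on the origin of the fluorine shift. Open, on these data alone, is whether this shift persists alongside the methoxy of compound 3, and how an amine or a carboxylic acid on this ring would read.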